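Swapping an Imidazolyl for an Isopropylcarbonyl Group

The compounds below may be only part of what the source reports. "The series", "measured", "known", "first", "only" and "open" are said of these compounds alone.

Of the compounds shown here, three built on one shared core have been tested in an assay on isolated protein for inhibition of serine protease 1 (Bos taurus); a lower number here means a stronger inhibitor, a higher number a weaker inhibitor. Compound 1 `Cc1c(F)c(Oc2cccc(NS(C)(=O)=O)c2)nc(Oc2cccc(C(=N)N)c2)c1F` gives 1900 nM, compound 2 `Cc1c(F)c(Oc2cccc(C(=N)N)c2)nc(Oc2cccc(C(=O)N3CCCC3)c2)c1F` gives 2800 nM, and compound 3 `Cc1c(F)c(Oc2cccc(C(=N)N)c2)nc(Oc2cccc(-n3ccnc3)c2)c1F` gives 4800 nM. Compound 3 thus stands at the highest number of the three: the move a 2.5-fold higher number from compound 1 to compound 3 (0.40 log units; beyond the scatter) lies beyond the scatter, whereas the move a 1.7-fold higher number from compound 2 to compound 3 (0.23 log units; within the scatter) does not, and a 1.5-fold higher number from compound 1 to compound 2 (0.17 log units; within the scatter) likewise stays within it.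

Compound 4 `Cc1c(F)c(Oc2cccc(C(=N)N)c2)nc(Oc2cccc(C(=O)C(C)C)c2)c1F` has not yet been measured in this assay. It differs from compound 3 in one place: isopropylcarbonyl in place of 1H-imidazol-1-yl on an aromatic carbon. Among the compounds with values here, the closest precedent is compound 2, which carries a carbonyl-bearing group in the same place; the step of a 1.7-fold higher number from compound 2 to compound 3 (0.23 log units; within the scatter) exchanged that carbonyl group for the imidazolyl and raised the number only within the scatter. Returning to a carbonyl group is therefore expected to change the number little, perhaps a shade downward. Compound 4 is expected to give about 3000 nM, with a range from 1200 nM to 7500 nM. That estimate corresponds to an expected step of a 1.6-fold lower number from compound 3 to compound 4 (0.20 log units; within the scatter).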

Compound 4, inhibition constant: 3800 nM
The estimate for compound 4 lay 1.3-fold (0.10 log units) below the measured number, within the range that was stated.
By their numbers in this assay, from the lowest: compounds 1, 2, 4 and 3 (each within the scatter of the next, the first and the last beyond it).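

The step of a 1.3-fold lower number from compound 3 to compound 4 (0.10 log units; within the scatter) shows that a group with no ring can replace the 1H-imidazol-1-yl on this aromatic carbon without a change that stands clear of the scatter. The step of a 1.4-fold higher number from compound 2 to compound 4 (0.13 log units; within the scatter) adds that, with the carbonyl kept, isopropyl and pyrrolidin-1-yl on the carbonyl carbon cannot be told apart, so the ring of compound 2 is not needed to hold the number in this range. The step of a 2.0-fold higher number from compound 1 to compound 4 (0.30 log units; within the scatter) also stays within the scatter, and no evidence at hand explains why these different groups give such similar numbers.

As far as these compounds go, whether a primary amine or a carboxylic acid on this aromatic carbon would move the number beyond the scatter remains open. So does the effect of a longer chain on the carbonyl carbon.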